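The source may report more compounds than this note shows. Statements on the series, on what has been measured and on what is new or still open speak of the compounds shown alone.

Series notes. The shared core of compound 1 `O=C1NC(=S)/C(=C/c2ccc(Cl)cc2)S1` carries a chloro group on its aromatic ring. In a functional assay on HEp-2 cells (Homo sapiens) for cytotoxicity, read by MTT assay, with a stated time of 72 h, tested at 1.25 ug/mL (a higher number here means more inhibition of growth at the concentration tested, a lower number less inhibition of growth), compound 1 gives 0.92%. Two other ring substitution patterns have been measured under the same conditions. Compound 2 `O=C1NC(=S)/C(=C/c2cc(Cl)cc(Cl)c2Cl)S1` gives 12.6% in this assay, and compound 3 `O=C1NC(=S)/C(=C/c2ccccc2F)S1` gives -8.34%. Of these three numbers the value of compound 1 is the second highest; it lies within the scatter of the value of compound 3, so no order between compound 1 and compound 3 can be read, whereas the value of compound 2 stands beyond the scatter above it. For the measured compounds named here, no pair among the measured compounds differs in a single place, so no one-point step is available as a guide.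

Compound 4 `O=C1NC(=S)/C(=C/c2ccc(Cl)c(Cl)c2)S1` is the next member to be tested. Relative to compound 1 the change is chloro in place of hydrogen on an aromatic carbon. With no matched step to lean on, the expectation rests on compound 2, whose extra chloro groups go together with the highest number shown, 12.6%. A step upward from compound 1 is therefore expected, but one that stays within the scatter: the estimated step is a number 5.1 percentage points higher from compound 1 to compound 4 (within the scatter). For compound 4 in this assay the estimate is 6%, with a range from -8% to 20%.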

Compound 4, percent growth inhibition at one concentration: -5.45%
For compound 4 the middle estimate is 11.5 percentage points above the measured one; low and high end bracket the measured number.
By their numbers in this assay, from the lowest: compounds 3, 4 and 1 (each within the scatter of the next); then compound 2.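

In this assay, for the compounds shown here, chloro in place of hydrogen, on an aromatic carbon ortho to a chloro group and meta to a group of 8 heavy atoms, gives the first one-place step, a number 6.4 percentage points lower from compound 1 to compound 4 (within the scatter), and this step stands within the scatter. At this position, then, the change leaves no readable shift in growth inhibition at the single concentration tested, and a chloro group here cannot be said to move the number either way. No measurement at hand bears on the reason for this result.

Still open, from the compounds shown here alone, is whether this aromatic carbon tolerates any group without a readable shift, or whether that holds only for chloro; an amine, a carboxylic acid or a methoxy group at the same place would test this. Going by these compounds alone, also open is whether the same chloro group gives a readable step when the chloro group of compound 1 is absent, since the one step at hand starts from compound 1 alone.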